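Aromatic Ring Substituents in a Cytotoxic Polyketide Series

The compounds below may be only part of what the source reports. "The series", "measured", "known", "first", "only" and "open" are said of these compounds alone.

Compound 1 `C=C/C=C\[C@H](C)[C@H](OC(N)=O)[C@@H](C)[C@H](O)[C@@H](C)C/C(C)=C\[C@H](C)[C@@H](O)[C@@H](C)/C=C\CCc1ccccc1`: 350 nM
Compound 2 `C=C/C=C\[C@H](C)[C@H](OC(N)=O)[C@@H](C)[C@H](O)[C@@H](C)C/C(C)=C\[C@H](C)[C@@H](O)[C@@H](C)/C=C\CCc1cccc(OC)c1`: 370 nM
Compound 3 `C=C/C=C\[C@H](C)[C@H](OC(N)=O)[C@@H](C)[C@H](O)[C@@H](C)C/C(C)=C\[C@H](C)[C@@H](O)[C@@H](C)/C=C\CCc1cccc(F)c1`: 400 nM

In a functional assay on SK-OV-3 cells (Homo sapiens) for cytotoxicity (a lower number here means a stronger inhibitor, a higher number a weaker inhibitor), compound 3 gives the highest number of the three, yet its steps from the others are small: a 1.1-fold higher number from compound 1 to compound 3 (0.06 log units; within the scatter) and a 1.1-fold higher number from compound 2 to compound 3 (0.03 log units; within the scatter), both within the scatter. Compound 4 `C=C/C=C\[C@H](C)[C@H](OC(N)=O)[C@@H](C)[C@H](O)[C@@H](C)C/C(C)=C\[C@H](C)[C@@H](O)[C@@H](C)/C=C\CCc1ccc(C)c(O)c1` keeps the shared core and changes only the aromatic ring: 3-hydroxy-4-methylphenyl in place of 3-fluorophenyl on a saturated chain carbon, two bonds along the chain from a double-bonded chain carbon. The measured steps on that same ring, a 1.1-fold higher number from compound 1 to compound 2 (0.02 log units; within the scatter) and a 1.1-fold higher number from compound 1 to compound 3 (0.06 log units; within the scatter), all stayed within the scatter, so no step beyond the scatter is expected here either. Compound 4 is therefore estimated at 400 nM in this assay, within 200 nM to 800 nM, a step of no change at the digits printed from compound 3 to compound 4 (within the scatter).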

Compound 4, half-maximal inhibitory concentration: 410 nM
Beside the measured number, compound 4's estimate is 1.0-fold (0.01 log units) below it, and the stated range covers the measured number.
By their numbers in this assay, from the lowest: compounds 1, 2, 3 and 4 (each within the scatter of the next).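

In this assay, the 3-hydroxy-4-methylphenyl group brings a hydrogen-bond donor to the ring, which the 3-fluorophenyl group lacks, yet every new step stays within the scatter: (a 1.0-fold higher number from compound 3 to compound 4 (0.01 log units; within the scatter)), (a 1.1-fold higher number from compound 2 to compound 4 (0.04 log units; within the scatter)) and (a 1.2-fold higher number from compound 1 to compound 4 (0.07 log units; within the scatter)). Going by these compounds alone, two ring changes made together therefore leave the number as flat as the single changes did. Nothing available explains this flat response. Still open, from the compounds shown here alone, is whether an amine or a carboxylic acid on the ring, or a longer chain leading to it, would move the number beyond the scatter.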